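A few compounds are considered here, and "the series" means these few. Any claim that something is new, unique, unknown or untested is made for them only; others in the source may bear on it.

Compound 1 `COc1cc(/C=N/Nc2nc(-c3ccc(C(F)(F)F)cc3)cs2)c(Br)c(Br)c1OC` belongs to a small set of hydrazone-linked compounds tested in a functional assay on U-87MG ATCC cells for inhibition, with U-87 MG (Homo sapiens) as the target, read by MTT assay, with a stated time of 48 h; a higher number here means a weaker inhibitor, a lower number a stronger inhibitor. In this assay compound 1 gives > 100000 nM, which is a limit of the assay and not a measured number. Compound 1 therefore stands at the limit of > 100000 nM in this assay, at which 2 of the 3 values shown sit, so its true potency is not known, only that it is weak. Compound 2 `COc1cc(/C=N/Nc2nc(-c3cc(C(F)(F)F)cc(C(F)(F)F)c3)cs2)cc(Br)c1OC` in this assay gives > 100000 nM, again a limit rather than a number. Compound 3 `COc1ccccc1-c1csc(N/N=C/c2ccc(F)c(F)c2)n1`, whose pieces are arranged differently around the shared core, gives 40600 nM in this assay, a real number, though still a weak one.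

The compound not yet measured, compound 4 `COc1cc(/C=N/Nc2nc(-c3ccc(F)c(F)c3)cs2)c(Br)c(Br)c1OC`, differs from compound 1 by 3,4-difluorophenyl in place of 4-(trifluoromethyl)phenyl on an aromatic carbon. Within the data shown here, no step between two measured compounds is available here, so the size of this change cannot be read from a direct comparison. The step from compound 1 to compound 4 is expected to be an at least 1.1-fold lower number from compound 1 to compound 4 (0.04 log units; that floor lies within the scatter), at most modest and possibly within the scatter, with a weak inhibitor still likely, since compound 3 carrying the same 3,4-difluorophenyl gives only 40600 nM. Compound 4 is estimated at 90000 nM in this assay, within a range from 30000 nM to 300000 nM.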

Compound 4, half-maximal inhibitory concentration: 19600 nM
For compound 4 the middle estimate is 4.6-fold (0.66 log units) above the measured one; the measured number lies below the stated range.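

In this assay, among these compounds, this is the first direct reading of a change at this position, the aromatic carbon next to the ring nitrogen of the five-membered ring: an at least 5.1-fold lower number from compound 1 to compound 4 (0.70 log units; beyond the scatter). Among the compounds shown here, with the rest of the molecule unchanged, replacing 4-(trifluoromethyl)phenyl with 3,4-difluorophenyl gives a real number in place of a limit, so the group at this position clearly affects the read-out, which the earlier compounds alone could not show. The value of compound 1, > 100000 nM, is a limit and not a number, so the step is only a lower bound on the true change, and its full size remains unknown because of this limit: the limit of > 100000 nM in this assay, at which 2 of the 4 values shown sit.

Going by these compounds, only these two groups can be compared at this position, so it remains open whether a plain phenyl ring, a phenyl ring bearing a single fluorine, or one carrying an amine or a carboxylic acid would give a lower or a higher number. On these data alone, it also remains open whether 3,4-difluorophenyl would have a similar effect on the differently substituted core of compound 2.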